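A few compounds are considered here, and "the series" means these few. Any claim that something is new, unique, unknown or untested is made for them only; others in the source may bear on it.

Compound 1 `COc1cc2ncnc(Nc3ccc(F)c(Cl)c3)c2cc1OCCCCC(=O)Nc1ccc(S(N)(=O)=O)cc1`: 15500 nM
Compound 2 `COc1cc2ncnc(Nc3cccc(Br)c3)c2cc1OCCCCC(=O)Nc1ccc(S(N)(=O)=O)cc1`: 14900 nM
Compound 3 `NS(=O)(=O)c1ccc(NC(=S)Nc2ccc3ncnc(Nc4ccc(F)c(Cl)c4)c3c2)cc1`: > 40000 nM

All three were tested in a functional assay on A549 cells (Homo sapiens) for antiproliferative activity, read by MTT assay, with a stated time of 72 h; on this read-out lower numbers stand for stronger inhibition and higher numbers for weaker inhibition. Compound 1 gives 15500 nM and compound 2 gives 14900 nM, and the step of a 1.0-fold lower number from compound 1 to compound 2 (0.02 log units; within the scatter) lies within the scatter. For compound 3 the assay reports only a limit, > 40000 nM, as recorded in the limit of > 40000 nM in this assay, at which 1 of the 3 values shown sits; compound 3 thus stands at the edge of what the assay can resolve, with no number obtained for it. Compound 4 `NS(=O)(=O)c1ccc(NC(=S)Nc2ccc3ncnc(Nc4cccc(F)c4)c3c2)cc1` is the unmeasured partner of compound 3, and the change is 3-fluorophenyl in place of 3-chloro-4-fluorophenyl on a nitrogen on an aromatic ring. Within the data shown here, the one measured step that bears on the same place, a 1.0-fold lower number from compound 1 to compound 2 (0.02 log units; within the scatter), is an exchange of the ring on that nitrogen and moved the number within the scatter. With compound 3 already at the limit, the step in this assay is expected to be none beyond the scatter, and the reading is likely again to be a limit. The estimated step that the limit leaves unreadable from compound 3 to compound 4 expresses this expectation. Compound 4 is therefore estimated at 50000 nM, with a range from 20000 nM to 150000 nM.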

Compound 4, half-maximal inhibitory concentration: 25900 nM
The estimate for compound 4 lay 1.9-fold (0.29 log units) above the measured number; the measured number falls inside the stated range.
By their numbers in this assay, from the lowest: compounds 2, 1 and 4 (each within the scatter of the next). At a limit, above all of these: compound 3.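

In this assay compound 3 stands at > 40000 nM, which is a limit of the assay and not a number. With 3-fluorophenyl in place of 3-chloro-4-fluorophenyl on that nitrogen, compound 4 gives a readable value of 25900 nM, and the result is an at least 1.5-fold lower number from compound 3 to compound 4 (0.18 log units; that floor lies within the scatter). Until now an exchange at this place had been seen only on the core of compound 1, and here the true size of the step stays unknown because one end of it is not a number: the limit of > 40000 nM in this assay, at which 1 of the 4 values shown sits.

The compounds shown leave open whether this exchange moves the number beyond the scatter on this core. They also leave open what a 3-chlorophenyl or 3-ethynylphenyl group on that nitrogen would give with the rest of compound 4 unchanged, or what a urea would give in place of its thiourea.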